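This account rests on a few compounds, and the source may have more. Where it says the series, first, only, none or still open, it means among the compounds named here.

Measured in an assay on CHO cells for displacement of a labelled ligand from adenosine receptor A1 (Homo sapiens), read by scintillation counting, with a stated time of 1 h, tested at 1 uM; on this read-out lower numbers stand for less inhibition and higher numbers for more inhibition at the one concentration tested (going by the name of the read-out):
- compound 1, `Nc1ncc(-c2ccccc2)c(-c2ccccc2)n1`, gives 32%.
- compound 3, `Nc1ncc(-c2ccc(C(F)(F)F)cc2)c(-c2ccccc2)n1`, gives 51%.
- compound 2, `Cc1cccc(-c2cnc(N)nc2-c2ccccc2)c1`, sits at the limit of > 80% in this assay, at which 1 of the 3 values shown sits, and so gives > 80%, a limit rather than a number.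

Compound 1 stands lowest of the two numbers shown. Its nearest neighbour is compound 3, with a number 19 percentage points higher from compound 1 to compound 3 (beyond the scatter), trifluoromethyl in place of hydrogen on an aromatic carbon. The remaining value is a limit. The step to compound 2, a number at least 48 percentage points higher from compound 1 to compound 2 (beyond the scatter), methyl in place of hydrogen on an aromatic carbon, is the larger of the two.

Compound 4, `Nc1ncc(-c2ccncc2)c(-c2ccccc2)n1`, differs from compound 1 by pyridin-4-yl in place of phenyl on an aromatic carbon. Neither measured step bears directly on this change: both keep the phenyl and put a substituent on an aromatic carbon, whereas here the ring itself is exchanged. They give no direction for the new step, so no change beyond the scatter is expected in this assay. For compound 4 the expected value in this assay is 30%, within 10% to 55%. The expected step is therefore a number 2 percentage points lower from compound 1 to compound 4 (within the scatter).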

Compound 4, a percentage reported as inhibition, at one concentration (the size of the read-out at that concentration, not a potency): > 80%
Compound 4: only a limit was reported; the forecaster's own chance of this, stated with the estimate: 3%; middle value at least 50 percentage points away from the limit.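

Exchanging the ring itself at this position, on an aromatic carbon para to an amino group, moves the read-out in this assay: pyridin-4-yl in place of phenyl gives a number at least 48 percentage points higher from compound 1 to compound 4 (beyond the scatter). The earlier steps shown here showed only substituents added to a retained phenyl, whereas here a ring nitrogen replaces a ring carbon at an unchanged count of 6 heavy atoms, and that exchange alone is enough for a large step. For compound 4, > 80% is a limit and not a number, so the full size of the step stays unread: the limit of > 80% in this assay, at which 2 of the 4 values shown sit.

Open, as far as these compounds go, is whether pyridin-3-yl or pyridin-2-yl at this position would follow pyridin-4-yl, and what an amine or a carboxylic acid on the ring would do. Ranking compound 4 against other changes at this position needs a read-out that is not capped at this limit.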